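The compounds below may be only part of what the source reports. "The series", "measured", "known", "first", "only" and "open" are said of these compounds alone.

In a functional assay on HCT-8 cells (Homo sapiens) for cytotoxicity (on this read-out lower numbers stand for an effect already at smaller amounts and higher numbers for an effect only at larger amounts of compound), compound 1 `CCc1ccc(/C=C/C(O)=C2/C(=O)C(C)=C(OC)C(C)(C)C2=O)cc1` gives 10.5 ug/mL and compound 2 `C=Cc1ccccc1/C=C/C(O)=C1/C(=O)C(C)=C(OC)C(C)(C)C1=O` gives 2.1 ug/mL, the lower of the two numbers. Compound 3 `COC1=C(C)C(=O)/C(=C(O)/C=C/c2nccs2)C(=O)C1(C)C` carries 1,3-thiazol-2-yl in place of 2-vinylphenyl on a double-bonded chain carbon bound to a double-bonded chain carbon. Among the compounds with values here, the only measured step at this place is a 5.0-fold lower number from compound 1 to compound 2 (0.70 log units; beyond the scatter), a modest one. A step of similar size is expected, toward a higher number, because compound 2 already stands lowest at 2.1 ug/mL. The expected change is a 2.4-fold higher number from compound 2 to compound 3 (0.38 log units; beyond the scatter). Compound 3 is estimated at 5 ug/mL, with a range from 1.5 ug/mL to 17 ug/mL.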

Compound 3, concentration for half-maximal effect: 5.1 ug/mL
For compound 3 the middle estimate is 1.0-fold (0.01 log units) below the measured one; low and high end bracket the measured number.
By their numbers in this assay, from the lowest: compound 2; then compound 3; then compound 1.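

In this assay, the place on a double-bonded chain carbon bound to a double-bonded chain carbon does not depend on a six-membered aromatic ring of carbon only. With 1,3-thiazol-2-yl there is a 2.4-fold higher number from compound 2 to compound 3 (0.39 log units; beyond the scatter) and a 2.1-fold lower number from compound 1 to compound 3 (0.31 log units; beyond the scatter), which puts compound 3 between compound 2 and compound 1. Nothing available explains this order. On these data alone, whether the nitrogen or the sulfur of the ring matters stays open. So does how a pyridin-2-yl or a 4-aminophenyl group would read at this place.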